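This account rests on a few compounds, and the source may have more. Where it says the series, first, only, none or still open, it means among the compounds named here.

Compound 1, whose structure is `O=C(NCCNS(=O)(=O)c1ccc(-c2ccccc2OCc2cccc(O)c2)s1)Nc1cc(Cl)cc(Cl)c1`, carries a (3,5-dichlorophenyl)carbamoyl group on an amine nitrogen whose other neighbours are a saturated chain carbon. In a functional assay on RS4-11 cells (Homo sapiens) for inhibition, read by CCK-8 assay, with a stated time of 48 h (a lower number here means a stronger inhibitor, a higher number a weaker inhibitor), compound 1 returns only a limit, > 50000 nM, and no number. Compound 2, `O=[N+]([O-])c1cccc(NC(=S)NCCNS(=O)(=O)c2ccc(-c3ccccc3OCc3cccc(O)c3)s2)c1`, has in place of that group a group of 12 heavy atoms (7 carbon, 2 nitrogen, 2 oxygen, 1 sulfur; one six-membered aromatic ring of carbon only), the change written as a group of 12 heavy atoms (7 carbon, 2 nitrogen, 2 oxygen, 1 sulfur; one six-membered aromatic ring of carbon only) in place of a group of 11 heavy atoms (7 carbon, 1 nitrogen, 1 oxygen, 2 chlorine; one six-membered aromatic ring of carbon only), on an amine nitrogen. In this assay compound 2 gives 9800 nM, and the step is an at least 5.1-fold lower number from compound 1 to compound 2 (0.70 log units; beyond the scatter). The exact size of that step is not fixed because the limit of > 50000 nM in this assay, at which 1 of the 3 values shown sits, is where compound 1 sits, a limit and not a number.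

Compound 3, `Cc1ccc(-c2ccsc2S(=O)(=O)NCCNC(=O)Nc2cc(Cl)cc(Cl)c2)c(Oc2ccc(O)c(O)c2)c1`, keeps the (3,5-dichlorophenyl)carbamoyl group but on a different core; how the cores of compound 1 and compound 3 differ is not broken down here. In this assay compound 3 gives 5100 nM, which lies within the scatter of the value of compound 2.

Compound 4, `Cc1ccc(-c2ccsc2S(=O)(=O)NCCNC(=S)Nc2cccc([N+](=O)[O-])c2)c(Oc2ccc(O)c(O)c2)c1`, applies the same change to compound 3, described as a group of 12 heavy atoms (7 carbon, 2 nitrogen, 2 oxygen, 1 sulfur; one six-membered aromatic ring of carbon only) in place of a group of 11 heavy atoms (7 carbon, 1 nitrogen, 1 oxygen, 2 chlorine; one six-membered aromatic ring of carbon only), on an amine nitrogen, at a place whose surroundings are worded identically for both pairs. The expected step from compound 3 to compound 4 is a 3.4-fold lower number from compound 3 to compound 4 (0.53 log units; beyond the scatter), resting on the measured step for compound 1 to compound 2, an at least 5.1-fold lower number from compound 1 to compound 2 (0.70 log units; beyond the scatter), whose true size is uncertain. Compound 4 is therefore estimated to give 1500 nM in this assay, expected between 400 nM and 6000 nM.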

Compound 4, half-maximal inhibitory concentration: 6100 nM
Beside the measured number, compound 4's estimate is 4.1-fold (0.61 log units) below it; measured number outside the range, above it.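

In this assay, the group of 12 heavy atoms replacing the (3,5-dichlorophenyl)carbamoyl group on the core of compound 3 gives a 1.2-fold higher number from compound 3 to compound 4 (0.08 log units; within the scatter), and this step does not match the one seen on the core of compound 1: the same change on two cores in this assay, an at least 5.1-fold lower number (0.70 log units; beyond the scatter) from compound 1 to compound 2 and a 1.2-fold higher number (0.08 log units; within the scatter) from compound 3 to compound 4, at least 6.1-fold (0.78 log units) apart, beyond the scatter of two such steps Compound 1 stands at a limit and not a number, so the earlier step has no exact size: the limit of > 50000 nM in this assay, at which 1 of the 4 values shown sits. With one pair on each core, these four compounds show that the outcome of this change depends on the core, but they do not show which feature of the cores matters or how the change would behave on a third core.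

Going by these compounds, the change itself bundles two replacements, a thiocarbonyl for a carbonyl and a nitro group for two chlorines, so it remains open which of them accounts for the step on the core of compound 1 and whether the two cancel on the core of compound 3. On these data alone, it is also open whether the same contrast between the cores would hold with a carboxylic acid in place of the nitro group, or with a longer chain on the amine nitrogen.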